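Benzimidazole-piperazine amides: isopropyl to ethyl on the benzoyl

A few compounds are considered here, and "the series" means these few. Any claim that something is new, unique, unknown or untested is made for them only; others in the source may bear on it.

Compound 1 `Cc1cccc(Cn2c(CN3CCN(C(=O)c4ccc(C(C)C)cc4)CC3)nc3ccccc32)c1` gives 67.6% in an assay on isolated protein for inhibition of aldehyde dehydrogenase 1A1 (Homo sapiens), read by spectrophotometry, tested at 10 uM (on this read-out lower numbers stand for less inhibition and higher numbers for more inhibition at the one concentration tested (going by the name of the read-out)), while compound 2 `O=C(C1CC1)N1CCN(Cc2nc3ccccc3n2Cc2ccccc2C(F)(F)F)CC1` gives 56.3% and compound 3 `Cc1ccc(Cn2c(CN3CCN(C(=O)C4CC4)CC3)nc3ccccc32)cc1` gives 51.5%. Compound 1 stands highest of the three numbers, and its distance to each of the other two is beyond the scatter. Among the measured compounds shown here, the single measured step, a number 4.8 percentage points lower from compound 2 to compound 3 (within the scatter), concerns the group on the benzylic carbon and does not touch the amide end. Compound 4 `CCc1ccc(C(=O)N2CCN(Cc3nc4ccccc4n3Cc3cccc(C)c3)CC2)cc1` differs from compound 1 only at that amide end: hydrogen in place of methyl on a saturated chain carbon bound to an aromatic carbon and a saturated chain carbon, that is, isopropyl to ethyl. For the measured compounds named here, no measured step bears on this change, so the expectation rests on compound 1 alone; the step from a number 4.6 percentage points lower from compound 1 to compound 4 (within the scatter) is expected to stay within the scatter. Compound 4 is estimated at 63%, with a range from 48% to 76%.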

Compound 4, a percentage reported as inhibition, at one concentration (the size of the read-out at that concentration, not a potency): 67%
Estimate against measurement, compound 4: 4 percentage points below, and the stated range covers the measured number.
By their numbers in this assay, from the lowest: compounds 3 and 2 (each within the scatter of the next); then compounds 4 and 1 (each within the scatter of the next).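

Among the compounds shown here, the change from 4-isopropylphenyl to 4-ethylphenyl gives the first measured step on this group: in this assay, the read-out is a number 0.6 percentage points lower from compound 1 to compound 4 (within the scatter). Removing this one methyl therefore produces no change that can be distinguished at this position, something the earlier step, which left this group untouched, could not show. No available evidence bears on this result. As far as these compounds go, what remains open is how a longer chain such as butyl would read in place of the ethyl, and whether an amine or a carboxylic acid there would hold the read-out.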